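A few compounds are considered here, and "the series" means these few. Any claim that something is new, unique, unknown or untested is made for them only; others in the source may bear on it.

In a functional assay on HeLa cells (Homo sapiens) for inhibition, read by MTT assay, with a stated time of 48 h (a higher number here means a weaker inhibitor of growth, a lower number a stronger inhibitor of growth), compound 1 `COc1ccc(C(=O)N2N=C(c3ccccc3)CC2c2cn(C)c3ccccc23)cn1` gives 3980 nM and compound 2 `COc1ccc2c(c1)c(C1CC(c3ccccc3)=NN1C(=O)c1cccnc1)cn2C` gives 3590 nM, so compound 2 stands level with compound 1, the two values lying within the scatter of each other. Compound 3 `COc1ccc2c(c1)c(C1CC(c3ccccc3)=NN1C(=O)c1ccc(OC)nc1)cn2C`, not yet measured, follows from compound 2 by one change, methoxy in place of hydrogen on an aromatic carbon. Among the compounds with values here, no measured step between compounds differing in one place is available as a guide, so no change beyond the scatter is expected, and the estimated move is a 1.2-fold lower number from compound 2 to compound 3 (0.08 log units; within the scatter). For compound 3 the estimated value is 3000 nM, with an expected range from 1200 nM to 7000 nM.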

Compound 3, concentration for 50% growth inhibition: 1100 nM
Estimate against measurement, compound 3: 2.7-fold (0.44 log units) above; measured number outside the range, below it.
By their numbers in this assay, from the lowest: compound 3; then compounds 2 and 1 (each within the scatter of the next).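

In this assay the change from pyridin-3-yl to 6-methoxypyridin-3-yl gives a 3.3-fold lower number from compound 2 to compound 3 (0.51 log units; beyond the scatter), so this place next to the ring nitrogen can shift the number beyond the scatter. Methoxy in place of hydrogen on the core gives a 3.6-fold lower number from compound 1 to compound 3 (0.56 log units; beyond the scatter), which shows that compound 3, carrying both methoxy groups, stands apart from the two compounds carrying one each. Nothing measured here accounts for either step.

On these data alone, whether an ethoxy group, an amine or a fluorine at this place would give a similar step remains open. So does the effect of this change on a core without methoxy.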